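The source may report more compounds than this note shows. Statements on the series, on what has been measured and on what is new or still open speak of the compounds shown alone.

In a functional assay on SW-620 cells (Homo sapiens) for inhibition (a lower number here means a stronger inhibitor, a higher number a weaker inhibitor), three compounds have been tested, and none of them gave a number. Compound 1 `CC(O)n1cnc2c(N)nc(I)nc21` reached only a limit, > 500000 nM. Compound 2 `Nc1nc(I)nc2c1ncn2OCCO` also stayed at a limit, > 500000 nM. Compound 3 `CC(O)n1cnc2c(S)nc(F)nc21` likewise gave a limit, > 500000 nM. Compound 2 differs from compound 1 by 2-hydroxyethoxy in place of 1-hydroxyethyl on an aromatic nitrogen, and the step that the two limits leave unreadable from compound 1 to compound 2 cannot be sized, since both ends are limits; this is shown by the limit of > 500000 nM in this assay, at which 3 of the 3 values shown sit. Compound 4 `OCCOn1cnc2c(S)nc(F)nc21` is not yet measured; it differs from compound 3 by the same change, (2-hydroxyethoxy in place of 1-hydroxyethyl on an aromatic nitrogen). How the core of compound 3 differs from the core of compound 1 is not broken down here. Since compound 3 sits at a limit of > 500000 nM, compound 4 is expected to stay weak, a step that the limit leaves unreadable from compound 3 to compound 4. The estimate for compound 4 in this assay is 1000000 nM, between 300000 nM and 5000000 nM.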

Compound 4, half-maximal inhibitory concentration: > 500000 nM
Compound 4: only a limit was reported; the forecaster's own chance of this, stated with the estimate: 85%; the middle value is on the limit's open side.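

For the compounds shown here, compound 3 and compound 4 both stand at limits, so no step between them can be read: the limit of > 500000 nM in this assay, at which 4 of the 4 values shown sit. The compounds shown leave open how strong any of them truly is in this assay and whether swapping 1-hydroxyethyl for 2-hydroxyethoxy changes anything.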